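Changing the Amide Aryl Group of a Weak Inhibitor

The source may hold more compounds than are shown below. What is called first, only, known or untested is meant among the compounds shown, and "the series" means these compounds.

Of the compounds shown here, two have been measured so far. Compound 1 `CC(C)COc1ccc(NC(=O)CSc2nnc(Cc3nn(C)c(=O)c4ccccc34)n2C)cc1` and compound 2 `Cn1c(Cc2nn(C)c(=O)c3ccccc23)nnc1SCCCCCCCC(=O)Nc1ccccc1O` share the same core and differ only in what hangs from the amide nitrogen. In an assay on isolated protein (Mus musculus) for inhibition of IL15-IL15 receptor (Homo sapiens), read by resazurin assay, with stated times of 30 min and 2.5 days (on this read-out lower numbers stand for stronger inhibition and higher numbers for weaker inhibition), compound 1 gives 30000 nM, and compound 2 gives 27000 nM. Compound 1 has the higher of the two numbers, but the gap to compound 2 falls inside the usual scatter, so the two cannot be told apart on these data.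

Compound 3 `Cn1c(Cc2nn(C)c(=O)c3ccccc23)nnc1SCC(=O)Nc1ccc(F)cc1F` has not yet been measured. It differs from compound 1 by 2,4-difluorophenyl in place of 4-(isobutoxy)phenyl on an amide-type nitrogen. Among the compounds with values here, no measured pair shows what such a change does here, so there is no basis for expecting a shift beyond the scatter in either direction. Compound 3 is therefore expected to give 30000 nM in this assay, with a plausible range from 10000 nM to 90000 nM, which means an expected step of no change at the digits printed from compound 1 to compound 3 (within the scatter), effectively no change beyond the scatter.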

Compound 3, half-maximal inhibitory concentration: "not active" (no number reported)
Compound 3: no number reported, so the estimate cannot be set against anything.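

In this assay, within the data shown here, compound 3 is reported as not active, without a number, so no step from compound 1 to compound 3 can be read. No other data here bear on this result. As far as these compounds go, how 2,4-difluorophenyl compares with 4-(isobutoxy)phenyl on the amide nitrogen remains open.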